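Methyl on the fused core: one change seen twice

The source may hold more compounds than are shown below. What is called first, only, known or untested is meant among the compounds shown, and "the series" means these compounds.

compound 1 `c1ccc(-c2nc3ncccn3c2CN2CCCC2)cc1`: 70 nM
compound 2 `CC(C)(C)c1nc2ncccn2c1CN1CCCCC1`: 1490 nM
compound 3 `Cc1ccn2c(CN3CCCCC3)c(C(C)(C)C)nc2n1`: 350 nM

These numbers come from a functional assay on MDA-MB-231 cells (Homo sapiens) for inhibition, read by sulforhodamine B assay, with a stated time of 48 h; a higher number here means a weaker inhibitor of growth, a lower number a stronger inhibitor of growth. Compound 1 gives the lowest of the three; how its core differs from the core of compound 2 is not broken down here. From compound 2 to compound 3 the change is methyl in place of hydrogen on an aromatic carbon, and it gave a 4.3-fold lower number from compound 2 to compound 3 (0.63 log units; beyond the scatter). Compound 4 `Cc1ccn2c(CN3CCCC3)c(-c3ccccc3)nc2n1` differs from compound 1 by methyl in place of hydrogen on an aromatic carbon, the same change at the same place, now on the core of compound 1.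

For the measured compounds named here, a step of similar size is expected in this assay, resting on the single earlier case of a 4.3-fold lower number from compound 2 to compound 3 (0.63 log units; beyond the scatter); with only one instance the range is kept wide. Compound 4 is expected to give 25 nM, between 9 nM and 70 nM. The expected step is a 2.8-fold lower number from compound 1 to compound 4 (0.45 log units; beyond the scatter).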

Compound 4, concentration for 50% growth inhibition: 4830 nM
Compound 4: middle estimate off by 190-fold (2.29 log units), on the low side; the whole stated range lies below it.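

In this assay, methyl in place of hydrogen on an aromatic carbon gives a 69-fold higher number from compound 1 to compound 4 (1.84 log units; beyond the scatter), so on the core of compound 1 the number rises, whereas on the core of compound 2 it fell. The step therefore does not carry from one core to the other in this series, in size or in direction: the same change on two cores in this assay, a 4.3-fold lower number (0.63 log units; beyond the scatter) from compound 2 to compound 3 and a 69-fold higher number (1.84 log units; beyond the scatter) from compound 1 to compound 4, 290-fold (2.47 log units) apart, beyond the scatter of two such steps. This rests on one pair per core and shows neither which difference between the two cores sets the direction nor why the direction reverses.

On these data alone, whether a methoxy group or a longer chain at the same place would follow compound 3 or compound 4 remains open. Also open, as far as these compounds go, is how methyl behaves on a core that combines phenyl with piperidine or tert-butyl with pyrrolidine.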